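Working notes: 4-fluorobenzyl to propyl on the shared core

This account rests on a few compounds, and the source may have more. Where it says the series, first, only, none or still open, it means among the compounds named here.

Measured so far:
compound 1 `C=C1C(=O)O[C@H]2[C@H]1CC/C(COC(=O)Cn1cc(F)c(=O)n(Cc3ccc(F)cc3)c1=O)=C\CC[C@@]1(C)O[C@@H]21` gives 2730 nM
compound 2 `C=C1C(=O)O[C@H]2[C@H]1CC/C(COC(=O)Cn1cc(F)c(=O)n(Cc3ccccc3F)c1=O)=C\CC[C@@]1(C)O[C@@H]21` gives 3770 nM

Both numbers come from a functional assay on Bel-7402 cells (Homo sapiens) for antiproliferative activity, read by MTT assay, with a stated time of 72 h; a higher number here means a weaker inhibitor, a lower number a stronger inhibitor. Within the data shown here, compound 1 gives the lower of the two numbers, but its only neighbour sits within the scatter, a 1.4-fold higher number from compound 1 to compound 2 (0.14 log units; within the scatter), so no order between compound 1 and compound 2 is claimed.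

Compound 3 `C=C1C(=O)O[C@H]2[C@H]1CC/C(COC(=O)Cn1cc(F)c(=O)n(CCC)c1=O)=C\CC[C@@]1(C)O[C@@H]21` is not yet measured. It differs from compound 1 as follows: ethyl in place of 4-fluorophenyl on a saturated chain carbon bound to an aromatic nitrogen. Among the measured compounds shown here, the one measured step moves a fluorine around the aromatic ring and keeps the ring; it does not test removal of the ring, so no measured step speaks directly to the change from compound 1 to compound 3. The measured pair offers no direction, and the expected step is a 1.3-fold higher number from compound 1 to compound 3 (0.11 log units; within the scatter), that is, nothing beyond the scatter, with wide uncertainty. Compound 3 is estimated at 3500 nM, in the range 1200 nM to 10000 nM.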

Compound 3, half-maximal inhibitory concentration: 8580 nM
Beside the measured number, compound 3's estimate is 2.5-fold (0.39 log units) below it; low and high end bracket the measured number.
By their numbers in this assay, from the lowest: compounds 1 and 2 (each within the scatter of the next); then compound 3.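

In this assay, the earlier pair only moved a fluorine around the aromatic ring, and that gave no readable difference; removing the ring does. With a 3.1-fold higher number from compound 1 to compound 3 (0.50 log units; beyond the scatter) and a 2.3-fold higher number from compound 2 to compound 3 (0.36 log units; beyond the scatter) the change to propyl at this position reads as a loss of activity beyond the scatter, modest in size, and both steps start from fluorinated benzyl compounds that cannot be ordered against each other. Nothing at hand explains this loss.

The compounds shown cannot separate the loss of the aromatic ring from the shortening of the group, and a plain benzyl or a longer chain such as hexyl would bear on that. Also open, on these data alone, is how this position responds to an amine or a carboxylic acid at the end of the chain.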